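The source may hold more compounds than are shown below. What is called first, only, known or untested is meant among the compounds shown, and "the series" means these compounds.

Measured so far:
compound 1, `COc1ccc(-c2cc(N3CCC(CNS(N)(=O)=O)CC3)ncn2)cc1` — in a functional assay on HT-29 cells (Homo sapiens) for antiproliferative activity, read by sulforhodamine B assay, with a stated time of 48 h (on this read-out lower numbers stand for stronger inhibition of growth and higher numbers for weaker inhibition of growth), compound 1 gives > 100000 nM, a limit of the assay, not a number.
compound 2, `COc1ccccc1-c1cc(N2CCC(CNS(N)(=O)=O)CC2)ncn1` — in this assay compound 2 gives > 100000 nM, likewise a limit.

Compound 2 sits at the limit of > 100000 nM in this assay, at which 2 of the 2 values shown sit. The step that the two limits leave unreadable from compound 1 to compound 2 is left unreadable by the two limits.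

Compound 3, `COc1ccccc1-c1cc(N2CCC(CCNS(N)(=O)=O)CC2)ncn1`, differs from compound 2 by (sulfamoylamino)methyl in place of sulfamoylamino on a saturated chain carbon bound to a saturated ring carbon. Within the data shown here, no measured step bears on this change; the only step in hand is unreadable. In this assay compound 3 is therefore expected to stay at the same limit, with no step beyond the scatter, namely a number no higher from compound 2 to compound 3 (the limit leaves the size open). The estimate for compound 3 is 100000 nM, with a range of 30000 nM to 300000 nM.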

Compound 3, concentration for 50% growth inhibition: 74300 nM
Beside the measured number, compound 3's estimate is 1.3-fold (0.13 log units) above it; the range from low to high includes it.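

In this assay, compound 3 is the first compound shown to give a number rather than a limit, so the longer chain brings the series into a readable range, though only just. From the compounds shown here alone, the change from sulfamoylamino to (sulfamoylamino)methyl gives an at least 1.3-fold lower number from compound 2 to compound 3 (0.12 log units; that floor lies within the scatter), so the real size of the step stays unknown. The other two compounds remain at a limit, not a number: the limit of > 100000 nM in this assay, at which 2 of the 3 values shown sit.

The compounds shown leave open whether a still longer chain, such as 3-(sulfamoylamino)propyl, would shift the number further. They also leave open how an amine or a carboxylic acid in place of the sulfamoylamino group would read.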